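This account rests on a few compounds, and the source may have more. Where it says the series, first, only, none or still open, it means among the compounds named here.

In a physicochemical assay for lipophilicity (on this read-out higher numbers stand for higher lipophilicity and lower numbers for lower lipophilicity), compound 1 (`CNC(=O)c1ccc(S(N)(=O)=O)cc1`) gives -0.31 and compound 2 (`CCNC(=O)c1ccc(S(N)(=O)=O)cc1`) gives 0.03, the higher of the two numbers. Compound 3 (`CCCCNC(=O)c1ccc(S(N)(=O)=O)cc1`) differs from compound 2 by ethyl in place of hydrogen on a saturated chain carbon, two bonds along the chain from an amide-type nitrogen. For the measured compounds named here, one measured step bears on this, the modest rise a number 0.34 log units higher from compound 1 to compound 2 (beyond the scatter), which came with methyl in place of hydrogen further down the same chain. Ethyl is the larger group, so a larger upward step, beyond the scatter, is expected in this assay. The expected step is a number 0.77 log units higher from compound 2 to compound 3 (beyond the scatter). For compound 3 the estimated value is 0.8, within an expected range of 0.5 to 1.2.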

Compound 3, partition coefficient: 1.05
Compound 3: the middle estimate sits 0.25 log units below what was measured, and the stated range covers the measured number.
By their numbers in this assay, from the lowest: compound 1; then compound 2; then compound 3.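

In this assay ethyl in place of hydrogen at this position gives a number 1.02 log units higher from compound 2 to compound 3 (beyond the scatter) as a large step, against the modest a number 0.34 log units higher from compound 1 to compound 2 (beyond the scatter) seen with methyl. Taken together, the change to the longest chain here gives a number 1.36 log units higher from compound 1 to compound 3 (beyond the scatter) overall, so the number rises as the chain grows across these three compounds, with none going against it. Nothing available here explains this rise.

Going by these compounds, whether a longer chain such as hexyl would continue the climb remains open. So does the outcome for a branched chain, or for a chain ending in an amine or a carboxylic acid.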